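The source may hold more compounds than are shown below. What is called first, only, known or untested is meant among the compounds shown, and "the series" means these compounds.

Measured so far:
compound 1 `CC(C)(C)c1ccc(-c2ccc(-c3ccc(C(=N)N)cc3)o2)cc1` – 3700 nM
compound 2 `Cc1ccc(-c2ccc(-c3ccc(C(=N)N)cc3)o2)cc1` – 4800 nM
compound 3 `N=C(N)c1ccc(-c2ccc(-c3ccc([N+](=O)[O-])cc3)o2)cc1` – 3200 nM

In a functional assay on MCF7 cells (Homo sapiens) for cytotoxicity, read by MTT assay, with a stated time of 96 h (a higher number here means a weaker inhibitor, a lower number a stronger inhibitor), compound 2 gives the largest of the three numbers, yet the steps around it are small: a 1.3-fold higher number from compound 1 to compound 2 (0.11 log units; within the scatter) and a 1.5-fold lower number from compound 2 to compound 3 (0.18 log units; within the scatter) both sit within the scatter, as does a 1.2-fold lower number from compound 1 to compound 3 (0.06 log units; within the scatter). Compound 4 `N=C(N)c1ccc(-c2ccc(-c3cccc(F)c3)o2)cc1` is not yet measured. It differs from compound 2 by 3-fluorophenyl in place of 4-methylphenyl on an aromatic carbon. For the measured compounds named here, the steps that bear on this change are those that swap the group at the same place, and none of them moved the number beyond the scatter. A step within the scatter is therefore expected for compound 4, a 1.1-fold lower number from compound 2 to compound 4 (0.05 log units; within the scatter), in no particular direction. Compound 4 is estimated at 4300 nM, with a range from 2000 nM to 9000 nM.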

Compound 4, half-maximal inhibitory concentration: 2600 nM
Estimate against measurement, compound 4: 1.7-fold (0.22 log units) above; the range from low to high includes it.
By their numbers in this assay, from the lowest: compounds 4, 3, 1 and 2 (each within the scatter of the next).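

In this assay, for the compounds shown here, the first change that replaces the whole 4-methylphenyl group, here with 3-fluorophenyl, gives a 1.8-fold lower number from compound 2 to compound 4 (0.27 log units; within the scatter). Even with fluorine entering and the ring's group named at a different number, this step, like the three earlier ones, stays within the scatter, so the number has not yet responded to any change shown at this place. Nothing available here explains the result. The compounds shown leave open whether an amine or a carboxylic acid on this phenyl ring, or a longer chain in its stead, would move the number beyond the scatter.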